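A Fluorine Placed Ortho on the Benzyl Group

The source may report more compounds than this note shows. Statements on the series, on what has been measured and on what is new or still open speak of the compounds shown alone.

Of the compounds shown here, three share one core and have been measured in a functional assay on A549 cells (Homo sapiens) for cytotoxicity, read by MTT assay, with a stated time of 48 h; on this read-out lower numbers stand for stronger inhibition and higher numbers for weaker inhibition.

Compound 1, `O=c1ccoc2cc(OCc3cn(Cc4cccc(F)c4)nn3)ccc12`, gives > 100000 nM, which is a limit of the assay rather than a number.
Compound 2, `O=c1ccoc2cc(OCc3cn(Cc4ccc(Cl)cc4Cl)nn3)ccc12`, gives 5260 nM.
Compound 3, `O=c1ccoc2cc(OCc3cn(Cc4ccccc4)nn3)ccc12`, gives > 100000 nM, again a limit of the assay rather than a number.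

Compound 3 thus stands at the limit, with no number of its own; only compound 2 reaches a number, and an at least 19-fold higher number from compound 2 to compound 3 (1.27 log units; beyond the scatter) shows how far apart they sit. Compound 4, `O=c1ccoc2cc(OCc3cn(Cc4ccccc4F)nn3)ccc12`, differs from compound 3 by fluoro in place of hydrogen on an aromatic carbon, so the change reads benzyl to 2-fluorobenzyl. The nearest measured comparison is a single fluoro at another place on the same ring, and a step that the two limits leave unreadable from compound 1 to compound 3 because of the limit of > 100000 nM in this assay, at which 2 of the 3 values shown sit. Going by the values given here, the only step that reaches a number, an at least 19-fold lower number from compound 1 to compound 2 (1.27 log units; beyond the scatter), involves two chlorines on the ring rather than one fluorine. One fluoro on the ring is therefore expected to leave the value near the limit, and the expected step of a number no higher from compound 3 to compound 4 (the limit leaves the size open) is none beyond the scatter. Compound 4 is estimated at 100000 nM, between 30000 nM and 300000 nM, and most likely reported again only as a limit.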

Compound 4, half-maximal inhibitory concentration: 10800 nM
The estimate for compound 4 lay 9.3-fold (0.97 log units) above the measured number; measured number below the stated range.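

In this assay, fluoro in place of hydrogen, on an aromatic carbon ortho to a large group, gives an at least 9.2-fold lower number from compound 3 to compound 4 (0.96 log units; beyond the scatter), so a single added heavy atom at this position is enough to bring a measurable value where the unsubstituted benzyl compound gave none. Where the fluoro sits also counts, since 2-fluorophenyl in place of 3-fluorophenyl gives an at least 9.2-fold lower number from compound 1 to compound 4 (0.96 log units; beyond the scatter), although both compounds carry one fluoro on the same ring. The single fluoro comes close to the 2,4-dichlorophenyl group without quite matching it, with a 2.1-fold higher number from compound 2 to compound 4 (0.31 log units; beyond the scatter), a modest gap that still lies beyond the scatter.

Going by these compounds, the values of compound 1 and compound 3 are limits of the assay and not numbers, so the full size of the two steps that start from them stays open: the limit of > 100000 nM in this assay, at which 2 of the 4 values shown sit. On these data alone, how a single chloro, a methoxy group or an amine on that same ring carbon would read also remains open, and so does whether the gain belongs to fluoro itself or to any group at this position.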